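A few compounds are considered here, and "the series" means these few. Any claim that something is new, unique, unknown or untested is made for them only; others in the source may bear on it.

Measured so far in an ADME assay on MDBK cells (Bos taurus) for cytotoxicity; a higher number here means that more compound is tolerated, a lower number that less compound is tolerated:
Compound 1 `Cc1ccn(Cc2c(F)cccc2F)c2nc(-c3c(F)cccc3F)nc1-2`: > 100000 nM
Compound 2 `Fc1cccc(F)c1Cn1ccc2nc(-c3ccccc3)nc-2c1`: > 100000 nM
Compound 3 `COc1cccc(Cn2ccc3nc(-c4ccccc4)nc-3c2)c1`: > 100000 nM

All three entries are limits of the assay and not numbers, and the record shows (the limit of > 100000 nM in this assay, at which 3 of the 3 values shown sit). Compound 2 therefore stands only at its limit of > 100000 nM.

Compound 4 `COc1ccc(Cn2ccc3nc(-c4ccccc4)nc-3c2)cc1` has 4-methoxyphenyl in place of 2,6-difluorophenyl on a saturated chain carbon bound to an aromatic nitrogen. For the measured compounds named here, the one measured step bearing on this change is a step that the two limits leave unreadable from compound 2 to compound 3, which places 3-methoxyphenyl at the same position. That step gives no size to carry over, and none of the three compounds has yielded a readable number. No change beyond the usual scatter is thus expected in this assay, and no direction can be assigned. The expected change is a number no higher from compound 2 to compound 4 (the limit leaves the size open). Compound 4 is estimated at 100000 nM, with an expected range from 50000 nM to 200000 nM, and it may well report only a limit.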

Compound 4, half-maximal cytotoxic concentration: > 100000 nM
Compound 4: no number, only a limit; the forecaster's own chance of this, stated with the estimate: 85%; the middle value lies on the limit itself.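

In this assay compound 4 gives > 100000 nM, which is a limit and not a number. Neither the step from compound 2 to compound 4 nor the step from compound 3 to compound 4 can be read. The compounds shown leave open whether any of these groups changes the tolerated concentration at all: the limit of > 100000 nM in this assay, at which 4 of the 4 values shown sit.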